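The source may report more compounds than this note shows. Statements on the series, on what has been measured and on what is new or still open speak of the compounds shown alone.

Compound 1 `O=C(Nc1ccccc1)Oc1ccc(Cl)cc1C(=O)Nc1ccc(F)cc1`: > 20000 nM
Compound 2 `O=C(Nc1ccccc1)Oc1ccc(Cl)cc1C(=O)Nc1ccc(Br)cc1`: > 50000 nM
Compound 3 `O=C(NCc1ccccc1)Oc1ccc(Cl)cc1C(=O)Nc1ccc(C(F)(F)F)cc1`: > 125000 nM

In an ADME assay on HepG2 cells (Homo sapiens) for cytotoxicity, read by MTT assay (a lower number here means a stronger inhibitor, a higher number a weaker inhibitor), compound 3 gives > 125000 nM, which is a limit of the assay and not a number. Compound 4 `O=C(Nc1ccccc1)Oc1ccc(Cl)cc1C(=O)Nc1ccc(C(F)(F)F)cc1` has not yet been measured. It comes from compound 3 by one change, phenyl in place of benzyl on an amide-type nitrogen.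

Among the measured compounds shown here, no measured step makes this same swap. For the measured compounds named here, the only measured step is a step that the two limits leave unreadable from compound 1 to compound 2, which is bromo in place of fluoro on an aromatic carbon, a different change whose size cannot be read. Compound 1 gives > 20000 nM, and this too is a limit. Compound 2 gives > 50000 nM, again a limit. With no number among the three readings, this assay offers no measured size to carry over, and the expectation can only be rough.

Compound 4 is expected to read as weak again, most likely as another limit. The expected change is an at least 2.0-fold lower number from compound 3 to compound 4 (0.31 log units; beyond the scatter), a direction that is only an estimate and follows the smaller limits of compound 1 and compound 2, not any measured effect of the swap. The estimate for compound 4 is 60000 nM, with an expected range from 20000 nM to 130000 nM.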

Compound 4, half-maximal inhibitory concentration: 9800 nM
Compound 4: middle estimate off by 6.1-fold (0.79 log units), on the high side; the measured number lies below the stated range.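

Among the compounds shown here, changing benzyl to phenyl on the amide-type nitrogen is the first change here with a readable direction in this assay: it brings an at least 12-fold lower number from compound 3 to compound 4 (1.10 log units; beyond the scatter), so the cells respond to what this nitrogen carries, at least with trifluoromethyl held in place on the other ring. With phenyl kept on that nitrogen, trifluoromethyl in place of bromo on the aromatic carbon brings an at least 5.1-fold lower number from compound 2 to compound 4 (0.70 log units; beyond the scatter), while trifluoromethyl in place of fluoro brings an at least 2.0-fold lower number from compound 1 to compound 4 (0.30 log units; that floor lies within the scatter), so only the former is a clear shift. These sizes are floors and not exact figures, and the largest rests on compound 3, whose reading is a limit: the limit of > 125000 nM in this assay, at which 1 of the 4 values shown sits.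

From the compounds shown here alone, the step between compound 1 and compound 2 cannot be read, so how bromo and fluoro compare in this test stays open, as does the true size of every step that starts from a limit. Going by these compounds, it is also open whether a longer chain such as phenylethyl on that nitrogen, or a carboxylic acid or an amine on the phenyl ring, would push the number lower or raise it again.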